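The compounds below may be only part of what the source reports. "The series", "measured", "known", "first", "only" and "open" are said of these compounds alone.

Of the compounds shown here, three sharing one core have been measured in a functional assay on MIA PaCa-2 cells (Homo sapiens) for inhibition, read by MTT assay, with a stated time of 7 days; a lower number here means a stronger inhibitor, a higher number a weaker inhibitor. Compound 1 `CCN(CC)S(=O)(=O)c1ccc(S(=O)(=O)N2CCC[C@@H](C(=O)N3CCC(F)(F)CC3)C2)cc1` gives 16 nM. Compound 2 `CCN(CC)S(=O)(=O)c1ccc(S(=O)(=O)N2CCC[C@@H](C(=O)N3CCS(=O)(=O)CC3)C2)cc1` gives 900 nM, and compound 3 `CCN(CC)S(=O)(=O)c1ccc(S(=O)(=O)N2CCC[C@@H](C(=O)N3CCC(C(F)F)CC3)C2)cc1` gives 420 nM. Compound 2 therefore stands at the highest number of the three, the weakest inhibition seen so far: the step of a 56-fold higher number from compound 1 to compound 2 (1.75 log units; beyond the scatter) is large, while the step of a 2.1-fold lower number from compound 2 to compound 3 (0.33 log units; beyond the scatter) is modest. Both of those steps exchange the group on the carbonyl carbon, and compound 4 `CCN(CC)S(=O)(=O)c1ccc(S(=O)(=O)N2CCC[C@@H](C(=O)N[C@H]3CCOC3)C2)cc1` alters the same place: (oxolan-3-yl)amino in place of 1,1-dioxothiomorpholin-4-yl on a carbonyl carbon. For the measured compounds named here, no measured compound carries an (oxolan-3-yl)carbamoyl group, so the earlier steps show only that this position matters strongly and that the 1,1-dioxothiomorpholin-4-yl group of compound 2 gives the highest number among the three. A lower number for compound 4 is expected because a 2.1-fold lower number from compound 2 to compound 3 (0.33 log units; beyond the scatter) already shows a lower number when that group is replaced, and the estimated step is a 2.0-fold lower number from compound 2 to compound 4 (0.30 log units; within the scatter). The size of the change is uncertain, since the replacements measured so far span from modest to large. Compound 4 is estimated at 450 nM, with a range from 100 nM to 2500 nM.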

Compound 4, half-maximal inhibitory concentration: 1670 nM
Compound 4: the middle estimate sits 3.7-fold (0.57 log units) below what was measured, and the stated range covers the measured number.
By their numbers in this assay, from the lowest: compound 1; then compound 3; then compounds 2 and 4 (each within the scatter of the next).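

In this assay, the (oxolan-3-yl)amino group is the first group on this carbonyl carbon shown with a hydrogen-bond donor and a five-membered ring, yet the result, a 1.9-fold higher number from compound 2 to compound 4 (0.27 log units; within the scatter), does not separate it from the 1,1-dioxothiomorpholin-4-yl group. Replacing that group therefore does not by itself give a lower number: compound 3 went that way by a modest step, while compound 4 cannot be told apart from compound 2. The other comparisons, a 4.0-fold higher number from compound 3 to compound 4 (0.60 log units; beyond the scatter) and a 100-fold higher number from compound 1 to compound 4 (2.02 log units; beyond the scatter), leave compound 1 and its 4,4-difluoropiperidin-1-yl group well apart from the other three compounds, so among these four groups only that one gives a number far below the rest.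

Nothing measured here accounts for these gaps. As far as these compounds go, it remains open whether a plain piperidin-1-yl or a morpholin-4-yl group on this carbonyl carbon would fall nearer to compound 1 or to compound 4, and whether the other stereoisomer of the (oxolan-3-yl)amino group, or a methyl group in place of the amide hydrogen, would shift the number.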